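The compounds below may be only part of what the source reports. "The series", "measured", "known", "first", "only" and "open" are said of these compounds alone.

Compound 1 `COc1cc2c(cc1OC)C(CC(N)=O)CC2` gives 31% in a functional assay on the whole organism (strain Wistar) for inhibition, with Rattus norvegicus as the target, read by paw edema, with stated times of 60 min and 2 h, at a dose of 100 mg/kg by the oral route; on this read-out lower numbers stand for less inhibition and higher numbers for more inhibition at the one dose given (going by the name of the read-out).
Compound 2 `CCNC(=O)CC1CCc2cc(OC)c(OC)cc21` gives 26% in this assay.
Compound 3 `CCN(CC)C(=O)CC1CCc2cc(OC)c(OC)cc21` gives 40% in this assay.

Among the three measured numbers compound 2 stands lowest. For the measured compounds named here, the step of a number 5 percentage points lower from compound 1 to compound 2 (within the scatter) lies within the scatter, as does a number 9 percentage points higher from compound 1 to compound 3 (within the scatter), whereas a number 14 percentage points higher from compound 2 to compound 3 (beyond the scatter) is the one step that goes beyond it, though only modestly.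

Compound 4 `COc1cc2c(cc1OC)C(CC(=O)N1CCNCC1)CC2` has not yet been measured in this assay. It differs from compound 2 in one place: piperazin-1-yl in place of ethylamino on a carbonyl carbon. The measured steps that bear on this change are those that alter the substitution on the amide-type nitrogen. Like compound 3, compound 4 carries no hydrogen on that nitrogen, and the only step beyond the scatter in this set, a number 14 percentage points higher from compound 2 to compound 3 (beyond the scatter), goes upward from compound 2. The step of a number 9 percentage points higher from compound 1 to compound 3 (within the scatter) points the same way without leaving the scatter. Going by the values given here, the entering piperazin-1-yl brings a ring and an extra hydrogen-bond donor that none of the measured compounds shows, so the closeness of the parallel is uncertain.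

Compound 4 is therefore expected to give 37%, within a range of 22% to 52%. The expected step is a number 11 percentage points higher from compound 2 to compound 4 (beyond the scatter), a modest rise in this assay.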

Compound 4, a percentage reported as inhibition, in the whole organism at one dose (the size of the read-out at that dose, not a potency): 44%
Compound 4: the middle estimate sits 7 percentage points below what was measured; measured number inside the range.
By their numbers in this assay, from the lowest: compounds 2, 1, 3 and 4 (each within the scatter of the next, the first and the last beyond it).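

With piperazin-1-yl on the carbonyl carbon, this assay shows a number 18 percentage points higher from compound 2 to compound 4 (beyond the scatter) and a number 13 percentage points higher from compound 1 to compound 4 (beyond the scatter), so this place accepts a six-membered non-aromatic ring with two hetero atoms as well as the open-chain groups seen so far. Compound 4 thus stands clear of both compound 1 and compound 2, whereas compound 3 stands clear of compound 2 alone. The comparison with the open-chain diethylamino group gives a number 4 percentage points higher from compound 3 to compound 4 (within the scatter), so at this one dose the ring and diethylamino cannot be told apart. Nothing given here accounts for these differences.

From the compounds shown here alone, whether the ring itself or its second nitrogen carries the result stays open: a piperidin-1-yl or morpholin-4-yl group on the same carbonyl carbon would separate the two, and a 4-methylpiperazin-1-yl group would show what a substituent on that second nitrogen does. Going by these compounds, with a single dose behind each number, it also remains open whether compound 3 and compound 4 would stay together at other doses, or whether the order of compound 1 and compound 2 could be settled at all.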